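Compound 4: a halogen swap on the benzyl group

The compounds below may be only part of what the source reports. "The series", "measured", "known", "first", "only" and "open" are said of these compounds alone.

Compound 1 `CCNC(=O)N1CCN(C(=S)SCc2cn(Cc3ccccc3F)nn2)CC1` in a functional assay on SMMC-7721 cells (Homo sapiens) for cytotoxicity, read by MTT assay, with a stated time of 72 h (a lower number here means a stronger inhibitor, a higher number a weaker inhibitor), gives a limit of > 128000 nM. Compound 2 `CCN(C)C(=O)N1CCN(C(=S)SCc2cn(Cc3ccccc3F)nn2)CC1` gives 19700 nM. Compound 3 `CC(C)(C)NC(=O)N1CCN(C(=S)SCc2cn(Cc3ccccc3F)nn2)CC1` gives a limit of > 128000 nM.

Compound 1 therefore stands at the limit of this assay rather than at a number. The same limit is shared by most of the set (the limit of > 128000 nM in this assay, at which 2 of the 3 values shown sit). The two readable steps both change the group on the amide-type nitrogen: an at least 6.4-fold lower number from compound 1 to compound 2 (0.81 log units; beyond the scatter) and an at least 6.4-fold higher number from compound 2 to compound 3 (0.81 log units; beyond the scatter), while a step that the two limits leave unreadable from compound 1 to compound 3 cannot be sized.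

Compound 4 `CCNC(=O)N1CCN(C(=S)SCc2cn(Cc3ccc(Cl)cc3)nn2)CC1` differs from compound 1 by 4-chlorophenyl in place of 2-fluorophenyl on a saturated chain carbon bound to an aromatic nitrogen. Within the data shown here, no measured step touches this part of the molecule; all three changes sit on the amide-type nitrogen, so none of them bears on the swap of the benzyl halogen. Without any step at this position, compound 4 is expected to stay where compound 1 stands, most likely at the limit, with a number no higher from compound 1 to compound 4 (the limit leaves the size open). The estimate for compound 4 is 128000 nM, with a range from 30000 nM to 400000 nM.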

Compound 4, half-maximal inhibitory concentration: > 128000 nM
Compound 4: only a limit was reported (the forecaster's own chance of this, stated with the estimate: 65%); the middle value lies on the limit itself.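

In this assay compound 4 gives > 128000 nM, which is a limit. Among these compounds, compound 1 also stands at a limit, so no step from compound 1 to compound 4 can be read. The compounds shown leave open whether 2-fluorobenzyl and 4-chlorobenzyl differ at all, with most values at one limit: the limit of > 128000 nM in this assay, at which 3 of the 4 values shown sit.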